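A few compounds are considered here, and "the series" means these few. Any claim that something is new, unique, unknown or untested is made for them only; others in the source may bear on it.

Among the measured compounds shown here, compound 2 `COc1ccccc1S(=O)(=O)c1ccc(NC(=O)C(C)(O)C(F)(F)F)cc1` is the only compound with a proper number in a functional assay (Cavia porcellus) with sulfonylurea receptors; K-ATP channels (Homo sapiens) as the target (a lower number here means a stronger inhibitor, a higher number a weaker inhibitor), where compound 2 gives 1600 nM. Compound 1 `CC(O)(C(=O)Nc1ccc(S(=O)(=O)c2ccc(C#N)cc2)cc1)C(F)(F)F` gives only > 30000 nM there, which is a limit of the assay rather than a number. For the measured compounds named here, the single measured step, an at least 18-fold lower number from compound 1 to compound 2 (1.27 log units; beyond the scatter), is thus bounded by the limit of > 30000 nM in this assay, at which 1 of the 2 values shown sits. Compound 3 `CC(O)(C(=O)Nc1ccc(S(=O)(=O)c2cccc(Cl)c2)cc1)C(F)(F)F` differs from compound 2 by 3-chlorophenyl in place of 2-methoxyphenyl on a sulfonyl sulfur. Going by the values given here, only that one step bears on this change, and it shows that the group on the sulfonyl sulfur can move the number by a large amount. The 3-chlorophenyl of compound 3 matches neither the 2-methoxyphenyl of compound 2 nor the 4-cyanophenyl of compound 1, so the direction is uncertain, and a weakening is judged somewhat more likely than a gain. Compound 3 is estimated at 5000 nM in this assay, with a range from 1500 nM to 30000 nM. This estimate means an expected step of a 3.1-fold higher number from compound 2 to compound 3 (0.49 log units; beyond the scatter).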

Compound 3, half-maximal inhibitory concentration: 10000 nM
Estimate against measurement, compound 3: 2.0-fold (0.30 log units) below, within the range that was stated.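

Among the compounds shown here, the change from 2-methoxyphenyl to 3-chlorophenyl on the sulfonyl sulfur gives a 6.3-fold higher number from compound 2 to compound 3 (0.80 log units; beyond the scatter) and is the first step at this place between two proper numbers in this assay. The 3-chlorophenyl carries no hydrogen-bond acceptor, yet compound 3 still reads as a proper number, and compound 2 keeps the lowest number of the three. The comparison with the 4-cyanophenyl gives an at least 3.0-fold lower number from compound 1 to compound 3 (0.47 log units; beyond the scatter), and the size of that step remains only a bound: the limit of > 30000 nM in this assay, at which 1 of the 3 values shown sits.

On these data alone, compounds 2 and 3 differ both in the substituent and in where its name places it on the ring, so the share of each in the step stays open. As far as these compounds go, how a plain phenyl, with neither chlorine nor methoxy, or an aminophenyl would read on the sulfonyl sulfur also stays open.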